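This account rests on a few compounds, and the source may have more. Where it says the series, first, only, none or still open, it means among the compounds named here.

Measured in a functional assay on MCF7 cells (Homo sapiens) for cytotoxicity, read by MTT assay, with a stated time of 48 h; on this read-out higher numbers stand for weaker inhibition and lower numbers for stronger inhibition:
Compound 1 `C#CC1=CC[C@@]2(C)C(=C)CCC[C@]2(C)CC1`: 575000 nM
Compound 2 `C=C1CCC[C@]2(C)CCC(c3cn(-c4ccc(C(C)=O)cc4)nn3)=CC[C@@]12C`: 65400 nM
Compound 3 `C=C1CCC[C@]2(C)CCC(c3cn(CC(=O)Nc4ccc(C)cc4)nn3)=CC[C@@]12C`: 80100 nM

Compound 2 has the lowest number of the three, but it lies within the scatter of compound 3, while compound 1 stands beyond the scatter from it. Compound 4 `C=C1CCC[C@]2(C)CCC(c3cn(-c4ccc(C)cc4)nn3)=CC[C@@]12C` has methyl in place of acetyl on an aromatic carbon, para to a large group: methyl in place of acetyl on an aromatic carbon. Going by the values given here, no measured pair isolates this change. Compound 2 at 65400 nM and compound 3 at 80100 nM nevertheless share the core and show no separation, so no step beyond the scatter is expected in this assay. The expected change is a 1.1-fold higher number from compound 2 to compound 4 (0.06 log units; within the scatter), with any drift slightly upward. For compound 4 the estimate is 75000 nM, with an expected range of 35000 nM to 160000 nM.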

Compound 4, half-maximal inhibitory concentration: 54900 nM
Compound 4: the middle estimate sits 1.4-fold (0.14 log units) above what was measured, and the stated range covers the measured number.
By their numbers in this assay, from the lowest: compounds 4, 2 and 3 (each within the scatter of the next); then compound 1.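

In this assay, going by these compounds alone, the pair gives the first reading of a single change on this aromatic ring: a 1.2-fold lower number from compound 2 to compound 4 (0.08 log units; within the scatter). Methyl in place of acetyl, para to a large group, therefore gives no separation, and removing the acetyl with its hydrogen-bond acceptor has no effect that this read-out can resolve. Nothing measured here offers an explanation for this result. On these data alone, it remains open whether an amine or a carboxylic acid on this carbon would shift the number beyond the scatter.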